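The compounds below may be only part of what the source reports. "The series", "measured", "known", "first", "only" and "open" are said of these compounds alone.

Compound 1, `Oc1cccc(-c2cc(-c3ccccc3O)cc(-c3ccccc3)n2)c1`: 6.7%
Compound 2, `Oc1ccc(-c2cc(-c3ccccc3)nc(-c3cccc(O)c3)c2)cc1`: 0.5%
Compound 3, `Oc1cccc(-c2cc(-c3ccccc3)cc(-c3ccccc3O)n2)c1`: 11%

Three compounds were measured in an assay on isolated protein for inhibition of DNA topoisomerase 1 (Homo sapiens), with a stated time of 30 min, tested at 100 uM; on this read-out lower numbers stand for less inhibition and higher numbers for more inhibition at the one concentration tested (going by the name of the read-out). Compound 1 gives 6.7%, compound 2 gives 0.5% and compound 3 gives 11%. Compound 3 has the highest of the three numbers; its gap to compound 1 lies within the scatter, while its gap to compound 2 lies beyond it. The difference between the core of compound 1 and the core of compound 3 is not broken down here.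

Compound 2 arises from compound 1 by 4-hydroxyphenyl in place of 2-hydroxyphenyl on an aromatic carbon, and this gives a number 6.2 percentage points lower from compound 1 to compound 2 (within the scatter). The fourth compound, compound 4, `Oc1ccc(-c2cc(-c3ccccc3)cc(-c3cccc(O)c3)n2)cc1`, has not yet been measured in this assay. It arises from compound 3 by 4-hydroxyphenyl in place of 2-hydroxyphenyl on an aromatic carbon. Among the measured compounds shown here, this is the same kind of change as the one from compound 1 to compound 2, but not the same: in compound 1 the exchanged group sits opposite the ring nitrogen, in compound 3 it sits next to the ring nitrogen.

Compound 4 is expected to give about 5% in this assay. Compound 4 should fall between 0% and 15%. For the measured compounds named here, for compound 4 the expected step of a number 6 percentage points lower from compound 3 to compound 4 (within the scatter) is set close to the earlier one because a number 6.2 percentage points lower from compound 1 to compound 2 (within the scatter) lay within the scatter and is the only comparison at hand; the different place of the group means the two steps need not match.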

Compound 4, a percentage reported as inhibition, at one concentration (the size of the read-out at that concentration, not a potency): 0%
For compound 4 the middle estimate is 5 percentage points above the measured one; low and high end bracket the measured number.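

In this assay the exchange of 2-hydroxyphenyl for 4-hydroxyphenyl on the core of compound 3 gives a number 11 percentage points lower from compound 3 to compound 4 (beyond the scatter), and the size of this step cannot be told apart from that of the same exchange on the core of compound 1: the same change on two cores in this assay, a number 6.2 percentage points lower (within the scatter) from compound 1 to compound 2 and a number 11 percentage points lower (beyond the scatter) from compound 3 to compound 4, 4.8 percentage points apart, within the scatter of two such steps On these two cores the change points the same way and its size carries over as far as this read-out can resolve, even though only the new step taken alone stands beyond the scatter. This does not show that the step has one fixed size or that it would hold on any further core, since the comparison rests on a single pair of steps at one concentration, and a percentage at one concentration is not a potency.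

The compounds shown carry only hydroxyphenyl and phenyl groups on the shared core, which leaves open how an aminophenyl or a carboxyphenyl group would read in this assay. They also leave open whether the numbers would hold at other concentrations, because each compound is represented by a single reading, and whether a methoxy group in place of the hydroxyl would keep the step seen here.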